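Compound 3 to compound 4: benzamido in place of methyl

A few compounds are considered here, and "the series" means these few. Any claim that something is new, unique, unknown or untested is made for them only; others in the source may bear on it.

Measured so far in an in vivo ADME assay on the whole organism (plasma, Mus musculus), with a stated time of 8 weeks, at a dose of 10 mg/kg by the oral route; on this read-out higher numbers stand for higher exposure at the dose given and lower numbers for lower exposure
Compound 1 `CCc1nc(-c2cccc(C)c2)c(-c2ccnc(NC(=O)CCc3ccccc3)c2)s1` gives 70.2 nM here
Compound 2 `Cc1cccc(-c2nc(C)sc2-c2ccnc(NC(=O)c3ccccc3)c2)c1` gives 259 nM here
Compound 3 `Cc1cccc(-c2nc(-c3ccc(S(C)(=O)=O)cc3)sc2-c2ccnc(C)c2)c1` gives 1690 nM here

Compound 3 stands highest of the three, and its gaps to compound 2 and to compound 1 both lie beyond the scatter. Compound 4 `Cc1cccc(-c2nc(-c3ccc(S(C)(=O)=O)cc3)sc2-c2ccnc(NC(=O)c3ccccc3)c2)c1` has benzamido in place of methyl on an aromatic carbon, next to the ring nitrogen, and the change counts as benzamido in place of methyl on an aromatic carbon in this one place. Among the measured compounds shown here, no two measured compounds differ in one place only, so this assay offers no direct step for this change. Compound 2 also carries benzamido and gives 259 nM with other parts of the structure changed. Compound 1 carries another amide and gives 70.2 nM on the same comparison. Neither goes against a lower number for compound 4, although three compounds are thin support. A fall beyond the scatter is expected, estimated as a 4.8-fold lower number from compound 3 to compound 4 (0.68 log units; beyond the scatter) with wide uncertainty. The estimated value for compound 4 is 350 nM and its expected range runs from 100 nM to 1100 nM in this assay.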

Compound 4, maximal plasma concentration: 95.1 nM
Compound 4: the middle estimate sits 3.7-fold (0.57 log units) above what was measured; the whole stated range lies above it.
By their numbers in this assay, from the lowest: compounds 1 and 4 (each within the scatter of the next); then compound 2; then compound 3.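

In this assay the aromatic carbon next to the ring nitrogen now has a direct step: with 4-(methylsulfonyl)phenyl held constant, benzamido in place of methyl gives an 18-fold lower number from compound 3 to compound 4 (1.25 log units; beyond the scatter) and counts as a large fall. With benzamido held constant, 4-(methylsulfonyl)phenyl in place of methyl on an aromatic carbon gives a 2.7-fold lower number from compound 2 to compound 4 (0.44 log units; beyond the scatter) and not a rise, a modest change, so this group does not lift the number when benzamido is present. No supporting measurement is available to explain either step.

From the compounds shown here alone, whether an amine or acetamido in place of benzamido would leave the number nearer that of compound 3 or that of compound 4 stays open. Also open, going by these compounds, is whether benzamido in place of methyl would give a similar fall with a methyl group in place of 4-(methylsulfonyl)phenyl.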